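Notes on the chloro analogue of compound 2

The source may hold more compounds than are shown below. What is called first, only, known or untested is meant among the compounds shown, and "the series" means these compounds.

Measured so far in an ADME assay on TERT-RPE1 cells (Homo sapiens) for cytotoxicity, read by MTT assay, with a stated time of 72 h; on this read-out lower numbers stand for stronger inhibition and higher numbers for weaker inhibition:
- compound 1 `COc1ccc(/C=C2/CN(C)/C(=N/c3ccc(C(C)(C)C)cc3)S2)cc1` (23500 nM)
- compound 2 `COc1ccc(/C=C2/CN(C)/C(=N/c3ccc(C(F)(F)F)cc3)S2)cc1` (72000 nM)

Compound 2 stands higher of the two with 72000 nM on this read-out, and compound 1 is its nearest neighbour. Compound 3 `COc1ccc(/C=C2/CN(C)/C(=N/c3ccc(Cl)cc3)S2)cc1` still awaits measurement. The change is chloro in place of trifluoromethyl on an aromatic carbon and reads as chloro in place of trifluoromethyl on an aromatic carbon, para to a large group. For the measured compounds named here, one measured step bears on it, also an exchange of groups on an aromatic carbon: a 3.1-fold higher number from compound 1 to compound 2 (0.49 log units; beyond the scatter) for trifluoromethyl in place of tert-butyl, modest but beyond the scatter. Going by the values given here, no measured compound carries chloro, so this single step suggests a likely scale and no firm direction. A small move toward a lower number is expected in this assay and it may stay within the scatter, with compound 2 at the upper end of the two values. The expected change is a 1.5-fold lower number from compound 2 to compound 3 (0.18 log units; within the scatter) in this estimate. For compound 3 the estimated value is 48000 nM (expected range 20000 nM to 110000 nM).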

Compound 3, half-maximal inhibitory concentration: 39600 nM
For compound 3 the middle estimate is 1.2-fold (0.08 log units) above the measured one; low and high end bracket the measured number.
By their numbers in this assay, from the lowest: compounds 1, 3 and 2 (each within the scatter of the next, the first and the last beyond it).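

In this assay, chloro on this aromatic carbon, para to a large group, gives a 1.8-fold lower number from compound 2 to compound 3 (0.26 log units; within the scatter) and a 1.7-fold higher number from compound 1 to compound 3 (0.23 log units; within the scatter). Both steps lie within the scatter, so compound 3 cannot be told apart from compound 2 or from compound 1, even though the step of a 3.1-fold higher number from compound 1 to compound 2 (0.49 log units; beyond the scatter) lies beyond it; the chloro result therefore adds no separate level at this position, and the one clear difference remains the one between the tert-butyl and trifluoromethyl compounds. Going from the 4 heavy atoms of trifluoromethyl to the 1 heavy atom of chloro does not move the number beyond the scatter, which the earlier pair could not show, and no accompanying measurement offers an explanation for any of these numbers.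

The compounds shown leave open whether an amine or a carboxylic acid at this position, both with hydrogen-bond donors or acceptors unlike the three groups compared here, would give a number beyond the scatter from compound 3. They also leave open whether the same small steps would appear with a group other than the methoxy substituent of the shared core.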